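The source may report more compounds than this note shows. Statements on the series, on what has been measured and on what is new or still open speak of the compounds shown alone.

Compound 1, `Cc1ccc(-c2cnc(N)nc2-c2ccccc2)cc1`, gives 51% in an assay on CHO cells for displacement of a labelled ligand from adenosine receptor A1 (Homo sapiens), read by scintillation counting, with a stated time of 1 h, tested at 1 uM; a higher number here means more inhibition at the concentration tested (going by the name of the read-out), a lower number less inhibition.
Compound 2, `COc1ccc(-c2cnc(N)nc2-c2ccccc2)cc1OC`, gives > 80% in this assay, a limit of the assay rather than a number.
Compound 3, `CCCCC(=O)Nc1ncc(-c2cccc(Cl)c2)c(-c2ccccc2)n1`, gives 52% in this assay.

Of the two plain numbers, compound 3 stands highest, but compound 1 lies within the scatter of it, so no order between the two can be claimed. Compound 2 sits at the limit, (the limit of > 80% in this assay, at which 1 of the 3 values shown sits), and is therefore not a number to rank against the others.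

Compound 4, `Clc1cccc(-c2cnc(NCc3ccccc3)nc2-c2ccccc2)c1`, has not yet been measured in this assay. It differs from compound 3 in one place: benzyl in place of butylcarbonyl on a nitrogen on an aromatic ring. Among the measured compounds shown here, no measured pair among the three compounds changes this nitrogen in the same way, so there is no comparable step to lean on; the free amino of compound 1 and compound 2 and the amide of compound 3 are all that is known at that position.

With nothing pointing in either direction, the step from compound 3 to compound 4 is expected to be small, no larger than the scatter, and its size is estimated as a number 3 percentage points higher from compound 3 to compound 4 (within the scatter). Compound 4 is therefore expected to give about 55% in this assay, with a range from 25% to 80%.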

Compound 4, a percentage reported as inhibition, at one concentration (the size of the read-out at that concentration, not a potency): 16%
For compound 4 the middle estimate is 39 percentage points above the measured one, outside the stated range (below it).
By their numbers in this assay, from the lowest: compound 4; then compounds 1 and 3 (each within the scatter of the next). At a limit, above all of these: compound 2.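

Among the compounds shown here, this position turns out not to be indifferent to what it carries: in this assay, putting benzyl in place of butylcarbonyl on a nitrogen on an aromatic ring gives a number 36 percentage points lower from compound 3 to compound 4 (beyond the scatter) and is the first single change that can be read in this set. The change removes a carbonyl, the hydrogen-bond acceptor of the leaving group, and brings in a six-membered aromatic ring, so the two groups differ in more than one feature and this one step cannot assign the drop to either. Nothing measured here gives a reason for the step.

From the compounds shown here alone, whether the drop follows the loss of the carbonyl or the arrival of the ring stays open, and on the same nitrogen a benzoyl group, which holds both, or a plain pentyl chain, which holds neither, would separate the two. Also open, going by these compounds, is what a free amine on this nitrogen gives with the rest of compound 3 held fixed, since compound 1 and compound 2 differ from it elsewhere too.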